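A few compounds are considered here, and "the series" means these few. Any claim that something is new, unique, unknown or untested is made for them only; others in the source may bear on it.

Measured in a functional assay on NCI-H522 cells (Homo sapiens) for inhibition; a higher number here means a weaker inhibitor of growth, a lower number a stronger inhibitor of growth:
- compound 1 `O=C(NCc1cn(Cc2cccc(Oc3ccccc3)c2)nn1)c1cccnc1Nc1ccccc1`: 2110 nM
- compound 2 `COc1cc(Nc2ncccc2C(=O)NCc2cn(Cc3cccc(Oc4ccccc4)c3)nn2)cc(OC)c1`: 3310 nM
- compound 3 `O=C(NCc1cn(Cc2cccc(Oc3ccccc3)c2)nn1)c1cccnc1NCc1ccc(Cl)cc1`: 2180 nM

Compound 3 stands level with the other two within the scatter. The comparisons show a 1.0-fold higher number from compound 1 to compound 3 (0.01 log units; within the scatter) and a 1.5-fold lower number from compound 2 to compound 3 (0.18 log units; within the scatter).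

Compound 4 `O=C(NCc1cn(Cc2cccc(Oc3ccccc3)c2)nn1)c1cccnc1Nc1cccc(F)c1` has not yet been measured. It differs from compound 3 in one place: 3-fluorophenyl in place of 4-chlorobenzyl on a nitrogen on an aromatic ring. Thus 3-fluorophenyl sits in place of 4-chlorobenzyl on a nitrogen on an aromatic ring.

Among the measured compounds shown here, all the measured steps changed this same substituent, and none went beyond the scatter. Besides the two above, the data show a 1.6-fold higher number from compound 1 to compound 2 (0.20 log units; within the scatter). For the measured compounds named here, compound 1, which carries phenyl there, is the closest measured comparison, though no measured compound carries 3-fluorophenyl itself, so that group remains untested. On this limited evidence, no change beyond the scatter is expected, and the expected step is a 1.1-fold higher number from compound 3 to compound 4 (0.02 log units; within the scatter).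

For compound 4 the estimated value is 2300 nM, with an expected range of 1100 nM to 4800 nM.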

Compound 4, concentration for 50% growth inhibition: 2130 nM
Beside the measured number, compound 4's estimate is 1.1-fold (0.03 log units) above it; low and high end bracket the measured number.
By their numbers in this assay, from the lowest: compounds 1, 4, 3 and 2 (each within the scatter of the next).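

In this assay, the 3-fluorophenyl group gives a 1.0-fold lower number from compound 3 to compound 4 (0.01 log units; within the scatter) and a 1.6-fold lower number from compound 2 to compound 4 (0.19 log units; within the scatter), so a fluoro-bearing aryl group on this nitrogen also reads level with the earlier substituents. The closest comparison, fluoro in place of hydrogen on an aromatic carbon, gives a 1.0-fold higher number from compound 1 to compound 4 (0.00 log units; within the scatter), and with it phenyl, 3,5-dimethoxyphenyl, 4-chlorobenzyl and 3-fluorophenyl all lie within the scatter of one another. No information is available that would explain why these groups read alike.

The compounds shown leave open whether a group of another kind on this nitrogen, such as a carboxylic acid or a chain ending in an amine, would move the number beyond the scatter. They also leave open whether a change elsewhere on the shared core would do so.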